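The source may hold more compounds than are shown below. What is called first, only, known or untested is meant among the compounds shown, and "the series" means these compounds.

Three close relatives have been tested in a functional assay on MCF7 cells (Homo sapiens) for inhibition, with a stated time of 96 h (a lower number here means a stronger inhibitor, a higher number a weaker inhibitor), all carrying a thiophen-3-yl group on a shared core. Compound 1 `COc1cc(C(=O)c2cn(-c3cccc(C)c3)cc2-c2ccsc2)cc(OC)c1OC` gives 65 nM, the highest of the three numbers. Compound 2 `COc1cc(C(=O)c2cn(-c3ccc(C)cc3)cc2-c2ccsc2)cc(OC)c1OC` gives 4 nM, and compound 3 `COc1cc(C(=O)c2cn(-c3ccc(F)cc3)cc2-c2ccsc2)cc(OC)c1OC` gives 15 nM. Compound 1 is therefore the weakest inhibitor so far, with its steps to both others beyond the scatter.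

Going by the values given here, all the measured steps alter only the group on the ring nitrogen: a 16-fold lower number from compound 1 to compound 2 (1.21 log units; beyond the scatter), which is large, a 4.3-fold lower number from compound 1 to compound 3 (0.64 log units; beyond the scatter), which is modest, and a 3.8-fold higher number from compound 2 to compound 3 (0.57 log units; beyond the scatter), also modest. Compound 4 `COc1cc(C(=O)c2cn(-c3cccc(C)c3)cc2-c2ccccn2)cc(OC)c1OC` keeps the 3-methylphenyl group of compound 1 and changes a different place: pyridin-2-yl in place of thiophen-3-yl on an aromatic carbon.

Among the compounds with values here, no measured step touches this place, so the data give no direct guide to direction or size. Within the data shown here, they show only that one small swap elsewhere on these compounds can move the number clearly. A modest rise towards weaker inhibition is a cautious expectation, though a step the other way cannot be ruled out. The expected change is a 2.3-fold higher number from compound 1 to compound 4 (0.36 log units; beyond the scatter). For compound 4 the estimated value is 150 nM, with an expected range from 30 nM to 700 nM.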

Compound 4, half-maximal inhibitory concentration: 140 nM
Compound 4: the middle estimate sits 1.1-fold (0.03 log units) above what was measured; the measured number falls inside the stated range.
By their numbers in this assay, from the lowest: compound 2; then compound 3; then compound 1; then compound 4.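

Going by these compounds alone, the place on the shared core that carries the thiophen-3-yl group can now be read for the first time: in this assay, pyridin-2-yl in its place gives a 2.2-fold higher number from compound 1 to compound 4 (0.33 log units; beyond the scatter) with the 3-methylphenyl group held fixed. This place therefore responds to the ring it carries, even though a five-membered aromatic ring with 1 hetero atom gives way to a six-membered one with 1 hetero atom and the count of hydrogen-bond acceptors stays the same, yet the step is smaller than the one seen on the ring nitrogen, a 16-fold lower number from compound 1 to compound 2 (1.21 log units; beyond the scatter) in the same assay. Nothing measured here speaks to what lies behind the rise in the number.

One step cannot separate ring size from the swap of sulfur for nitrogen, and it cannot show whether pyridin-2-yl would move the number by a similar amount on compound 2, which carries the 4-methylphenyl group. A plain phenyl ring or a pyridin-3-yl ring at this place would help to pull these questions apart, while a small amine would test whether an aromatic ring is needed here at all.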